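A few compounds are considered here, and "the series" means these few. Any claim that something is new, unique, unknown or untested is made for them only; others in the source may bear on it.

Values so far, all from a physicochemical assay for solubility, at pH 7.4; on this read-out higher numbers stand for higher solubility and lower numbers for lower solubility

- compound 1 `O=C(/C=C/c1ccc(/C=C/C(=O)c2ccccc2)cc1)NO` gives 3000 nM
- compound 2 `CN1CCN(c2cccc(C(=O)/C=C/c3ccc(/C=C/C(=O)NO)nc3)c2)CC1` gives 104000 nM
- compound 3 `O=C(/C=C/c1cccc(/C=C/C(=O)c2ccccc2)c1)NO` gives 12000 nM

Compound 3 holds the middle place of the three numbers. Its value of 12000 nM lies above that of compound 1 and below that of compound 2, and both gaps are beyond the scatter.

Next in the series is compound 4 `CN1CCN(c2ccccc2C(=O)/C=C/c2cccc(/C=C/C(=O)NO)c2)CC1`, which departs from compound 3 by a single change (4-methylpiperazin-1-yl in place of hydrogen on an aromatic carbon): 4-methylpiperazin-1-yl in place of hydrogen on an aromatic carbon, ortho to a large group. Among the measured compounds shown here, no measured pair isolates this change, so its size has no direct measure. For the measured compounds named here, the only guide is compound 2, which also carries a 4-methylpiperazin-1-yl group and gives 104000 nM in this assay against the lower number of compound 3. Compound 2 differs from compound 3 in more than one place, so that gap cannot be assigned to the group alone, and the expectation stays cautious.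

In this assay an upward step is expected, estimated as a 4.2-fold higher number from compound 3 to compound 4 (0.62 log units; beyond the scatter) and beyond the scatter. Compound 4 is estimated at 50000 nM with a range of 15000 nM to 150000 nM expected.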

Compound 4, solubility: 177000 nM
Compound 4: middle estimate off by 3.5-fold (0.55 log units), on the low side; measured number above the stated range.
By their numbers in this assay, from the lowest: compound 1; then compound 3; then compounds 2 and 4 (each within the scatter of the next).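

In this assay, 4-methylpiperazin-1-yl in place of hydrogen on an aromatic carbon, ortho to a large group, gives a 15-fold higher number from compound 3 to compound 4 (1.17 log units; beyond the scatter) and is a large step. Among the compounds shown here, this is the first pair that isolates the change, so its size now has a direct measure instead of resting on compounds that differ in more than one place. The pair shows that this aromatic carbon can take a group of this size with the number moving upward well beyond the scatter, though that reading holds for this one position on the core of compound 3 and for this one group. Nothing at hand accounts for the size of the step.

Open, on these data alone, is whether a morpholin-4-yl group, a piperazin-1-yl group without the methyl, or a simple dimethylamino group on the same carbon would give a step of similar size. Also open, as far as these compounds go, is whether 4-methylpiperazin-1-yl on another carbon of that ring, or on the same ring in the core of compound 1, would repeat the step.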